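Swapping the benzyl arm for a small ring: compound 4

The source may report more compounds than this note shows. Statements on the series, on what has been measured and on what is new or still open speak of the compounds shown alone.

Measured compounds:
compound 1, `COc1ccc([C@@H]2CC(=O)c3c(O)cc(OCc4cn(Cc5ccccc5Cl)nn4)cc3O2)cc1O`, 6140 nM
compound 2, `COc1ccc([C@@H]2CC(=O)c3c(O)cc(OCc4cn(Cc5ccc(F)cc5)nn4)cc3O2)cc1O`, 15100 nM
compound 3, `COc1ccc([C@@H]2CC(=O)c3c(O)cc(OCc4cn(Cc5ccccc5)nn4)cc3O2)cc1O`, 11000 nM

The three measured compounds share one core and differ only in the group on a saturated chain carbon bound to an aromatic nitrogen. In a functional assay on RAW264.7 cells (Mus musculus) for inhibition, read by Griess assay, with stated times of 2 h and 24 h (on this read-out lower numbers stand for stronger inhibition and higher numbers for weaker inhibition), compound 1 gives the lowest of the three numbers; the step of a 1.8-fold higher number from compound 1 to compound 3 (0.25 log units; within the scatter) stays within the scatter, while the step of a 2.5-fold higher number from compound 1 to compound 2 (0.39 log units; beyond the scatter) is beyond it. The step of a 1.4-fold lower number from compound 2 to compound 3 (0.14 log units; within the scatter) is also within the scatter.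

Compound 4, `COc1ccc([C@@H]2CC(=O)c3c(O)cc(OCc4cn(CC5CC5)nn4)cc3O2)cc1O`, differs from compound 1 as follows: cyclopropyl in place of 2-chlorophenyl on a saturated chain carbon bound to an aromatic nitrogen. Among the compounds with values here, none of the measured steps removes the aromatic ring itself; they only change what sits on it, and the largest such step is a 2.5-fold higher number from compound 1 to compound 2 (0.39 log units; beyond the scatter). Since every change away from compound 1 has so far given a higher number, a higher number is also expected here, estimated as a 2.0-fold higher number from compound 1 to compound 4 (0.29 log units; within the scatter) in this assay. Compound 4 is thus expected to give about 12000 nM, with a range from 5000 nM to 30000 nM.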

Compound 4, half-maximal inhibitory concentration: 11900 nM
For compound 4 the middle estimate is 1.0-fold (0.00 log units) above the measured one; the measured number falls inside the stated range.
By their numbers in this assay, from the lowest: compounds 1, 3, 4 and 2 (each within the scatter of the next, the first and the last beyond it).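

Unlike the earlier steps, this change removes the aromatic ring itself from the position on a saturated chain carbon bound to an aromatic nitrogen, and in this assay the ring proves replaceable without a readable loss. Cyclopropyl in place of phenyl gives a 1.1-fold higher number from compound 3 to compound 4 (0.03 log units; within the scatter) and cyclopropyl in place of 4-fluorophenyl gives a 1.3-fold lower number from compound 2 to compound 4 (0.10 log units; within the scatter) while cyclopropyl in place of 2-chlorophenyl gives a 1.9-fold higher number from compound 1 to compound 4 (0.29 log units; within the scatter) so none of the three aromatic groups can be told apart from this small non-aromatic ring. No separate measurement bears on this result, so what lies behind it remains unknown.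

Every compound shown still carries a ring on this chain carbon, so whether any ring is needed stays open. An open chain such as butyl, or a group carrying an amine, could answer that question.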